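This account rests on a few compounds, and the source may have more. Where it says the series, first, only, none or still open, it means among the compounds named here.

Measured compounds in a functional assay on CHO-K1 cells for antagonist activity at transient receptor potential cation channel subfamily V member 1 (Homo sapiens), read by FLIPR; on this read-out lower numbers stand for stronger inhibition and higher numbers for weaker inhibition:
- compound 1, `CC(C(=O)NCc1ccc(C(F)(F)F)nc1Nc1ccc(F)cc1)c1ccc(NS(C)(=O)=O)c(F)c1`, gives 39.2 nM
- compound 2, `Cc1ccc(CC2CCN(c3nc(C(F)(F)F)ccc3CNC(=O)C(C)c3ccc(NS(C)(=O)=O)c(F)c3)CC2)cc1`, gives 0.2 nM
- compound 3, `CC(C(=O)NCc1ccc(C(F)(F)F)nc1N1CCC(C(=O)c2ccc(F)cc2)CC1)c1ccc(NS(C)(=O)=O)c(F)c1`, gives 3.9 nM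

Compound 1 stands at the highest number of the three; compound 3 gives a lower number than compound 1, and compound 2 a lower number still. Compound 4, `COC1CCN(c2nc(C(F)(F)F)ccc2CNC(=O)C(C)c2ccc(NS(C)(=O)=O)c(F)c2)CC1`, is not yet measured in this assay. It differs from compound 1 in one place: 4-methoxypiperidin-1-yl in place of (4-fluorophenyl)amino on an aromatic carbon.

Among the measured compounds shown here, only one measured step is available, and it does not touch the same place: a 20-fold higher number from compound 2 to compound 3 (1.29 log units; beyond the scatter). It shows that what sits on the saturated ring carbon of the piperidine moves the number over a wide span. Compounds 2 and 3 both carry a piperidin-1-yl where compound 1 carries the (4-fluorophenyl)amino, and both give lower numbers than compound 1, though each carries a larger group on the saturated ring carbon than the methoxy of compound 4. For compound 4 a lower number than compound 1 is therefore expected, as a step of a 4.9-fold lower number from compound 1 to compound 4 (0.69 log units; beyond the scatter), with a wide range because compound 3 gives 3.9 nM with a different substituent on that ring carbon. Compound 4 is estimated at 8 nM, between 2 nM and 30 nM.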

Compound 4, inhibition constant: 2.4 nM
For compound 4 the middle estimate is 3.3-fold (0.52 log units) above the measured one; low and high end bracket the measured number.
By their numbers in this assay, from the lowest: compound 2; then compounds 4 and 3 (each within the scatter of the next); then compound 1.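

In this assay the aromatic carbon next to the ring nitrogen proves sensitive to this exchange, with a 16-fold lower number from compound 1 to compound 4 (1.21 log units; beyond the scatter) on going to the 4-methoxypiperidin-1-yl, so the drop needs no large group on the piperidine. On the saturated ring carbon, methoxy and (4-fluorophenyl)carbonyl cannot be told apart, with a 1.6-fold lower number from compound 3 to compound 4 (0.21 log units; within the scatter), so among these compounds the aryl ketone brings nothing measurable over methoxy. Only 4-methylbenzyl stands clear of the other two groups, with a 12-fold higher number from compound 2 to compound 4 (1.08 log units; beyond the scatter), and the wide span on that carbon rests on compound 2 alone.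

Open, from the compounds shown here alone, is whether a piperidine with no substituent on that carbon keeps the low number. Also open, going by these compounds, is how a hydroxyl, a primary amine or a longer ether chain such as ethoxy would compare with methoxy. No measurement at hand accounts for any of these steps.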